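The source may report more compounds than this note shows. Statements on the series, on what has been measured and on what is new or still open speak of the compounds shown alone.

Working notes on the series. Of the compounds shown here, three of a shared core have been measured: compound 1 `Cc1nc(-c2ccc(Cl)cc2)sc1C(=O)CSc1nc(-c2ccccc2)c(C#N)c(=O)[nH]1`, compound 2 `COc1cccc(-c2nc(SCC(=O)c3sc(-c4ccccc4)nc3C)[nH]c(=O)c2C#N)c1` and compound 3 `Cc1nc(-c2ccccc2)sc1C(=O)CSc1nc(-c2ccccc2)c(C#N)c(=O)[nH]1`. In a functional assay on U-87MG ATCC cells for antiproliferative activity against U-87 MG (Homo sapiens), read by MTT assay, with a stated time of 48 h, tested at 10 uM (on this read-out lower numbers stand for a stronger effect and higher numbers for a weaker effect at the one concentration tested), compound 1 gives 83.1%, compound 2 gives 90.2% and compound 3 gives 87.5%; compound 1 holds the lowest of the three numbers, yet both others lie within the scatter of it. Compound 4 `Cc1nc(-c2ccc(Cl)cc2)sc1C(=O)CSc1nc(-c2ccc(Cl)cc2)c(C#N)c(=O)[nH]1` is not yet measured. It differs from compound 1 by chloro in place of hydrogen on an aromatic carbon. Going by the values given here, two measured steps bear on this, each a single substituent change on a phenyl group: a number 4.4 percentage points higher from compound 1 to compound 3 (within the scatter) and a number 2.7 percentage points lower from compound 2 to compound 3 (within the scatter), both within the scatter. A step of a number 2.1 percentage points lower from compound 1 to compound 4 (within the scatter) in this assay is therefore expected, nothing beyond the scatter. Compound 4 is estimated at 81%, with a range from 66% to 96%.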

Compound 4, a percentage reported as activity, at one concentration (the size of the read-out at that concentration, not a potency): 98.4%
For compound 4 the middle estimate is 17.4 percentage points below the measured one; measured number above the stated range.
By their numbers in this assay, from the lowest: compounds 1, 3, 2 and 4 (each within the scatter of the next, the first and the last beyond it).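

Phenyl to 4-chlorophenyl on the nitrile-bearing side of the molecule gives a number 15.3 percentage points higher from compound 1 to compound 4 (beyond the scatter) in this assay, the first single change in the series beyond the scatter, and it points to a weaker effect. Chloro on the other phenyl group behaves differently in this one pair, with a number 4.4 percentage points higher from compound 1 to compound 3 (within the scatter) on its removal. Nothing available explains the step.

As far as these compounds go, whether an amine or a carboxylic acid at this position would lower the number remains open. Also open, from the compounds shown here alone, is whether the 4-chlorophenyl step holds when the other phenyl group carries no chloro.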